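The compounds below may be only part of what the source reports. "The series", "measured", "known", "first", "only" and "open" are said of these compounds alone.

Two compounds share one core and are tested in a functional assay on the whole organism (strain albino) for inhibition, with Rattus norvegicus as the target, read by paw edema, with stated times of 30 min and 3 h, at a dose of 0.28 mmol/kg by the oral route; a higher number here means more inhibition at the dose given (going by the name of the read-out), a lower number less inhibition. Compound 1, `C=CCn1c(SCC(=O)Nc2ccc(C(C)=O)cc2)nnc1-c1ccccc1`, gives 54% there. Compound 2, `CCn1c(SCC(=O)Nc2ccc(C(C)=O)cc2)nnc1-c1ccc(OC)cc1`, gives 57% in this assay. These two numbers lie within the usual scatter of each other, so neither compound can be set above the other on this evidence.

Compound 3, `CCn1c(SCC(=O)Nc2ccc(C(C)=O)cc2)nnc1-c1ccccc1`, has not yet been measured. It differs from compound 2 in one place: hydrogen in place of methoxy on an aromatic carbon. Among the measured compounds shown here, no pair of measured compounds differs in just one place, so there is no measured step to lean on. The one point of reference is the compound that carries the same unsubstituted phenyl ring as compound 3: in this assay compound 1 gives 54%.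

For compound 3 in this assay the expectation is a step of a number 2 percentage points lower from compound 2 to compound 3 (within the scatter), no change beyond the scatter. Compound 3 is therefore estimated at 55%, with a range from 42% to 66%.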

Compound 3, a percentage reported as inhibition, in the whole organism at one dose (the size of the read-out at that dose, not a potency): 56%
Compound 3: middle estimate off by 1 percentage points, on the low side; the range from low to high includes it.
By their numbers in this assay, from the lowest: compounds 1, 3 and 2 (each within the scatter of the next).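

In this assay the swap from 4-methoxyphenyl to phenyl gives a number 1 percentage points lower from compound 2 to compound 3 (within the scatter) and so, at this one dose, the read-out at this position does not depend on the methoxy being present, as far as this pair shows. Compound 3 also provides a second single-place comparison, away from the aromatic ring: methyl in place of vinyl on a saturated chain carbon bound to an aromatic nitrogen gives a number 2 percentage points higher from compound 1 to compound 3 (within the scatter) and this change likewise stays inside the usual spread of repeat measurements. Nothing measured here explains why either change leaves the inhibition where it is.

Methoxy and hydrogen are the only two groups shown at the ring position, so it remains open whether a chlorine atom, a hydroxyl or an amine there would shift the number beyond the scatter. From the compounds shown here alone, it also remains open whether a longer chain, such as butyl, on the aromatic nitrogen would do so.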